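Swapping a Hydroxyamino Group for Benzylsulfanyl on the Core

The source may report more compounds than this note shows. Statements on the series, on what has been measured and on what is new or still open speak of the compounds shown alone.

Of the compounds shown here, two built on a shared core have been measured in a functional assay on MCF7 cells (Homo sapiens) for antiproliferative activity, read by MTT assay, with a stated time of 48 h; a lower number here means a stronger inhibitor, a higher number a weaker inhibitor. Compound 1, with structure `Cc1ccc(-c2nc(NO)c3cc(Cl)ccc3n2)cc1`, gives 6.81 ug/mL in this assay. Compound 2, with structure `Cc1ccc(-c2nc3ccc(Cl)cc3c(=S)o2)cc1`, gives 5.18 ug/mL in this assay. Compound 1 has the highest number of the two, but the gap to compound 2 lies within the usual scatter, so the two values cannot be told apart with confidence.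

Compound 3, with structure `Cc1ccc(-c2nc(SCc3ccccc3)c3cc(Cl)ccc3n2)cc1`, has not yet been measured. It differs from compound 1 in a single place: benzylsulfanyl in place of hydroxyamino on an aromatic carbon. In words, a benzylsulfanyl group takes the place of the hydroxyamino group on an aromatic carbon of the core.

Going by the values given here, no measured pair in this set shows what such a swap does to the numbers in this assay, so the direction of the step is open. Without such guidance the expectation for the step from compound 1 to compound 3 is a 1.0-fold lower number from compound 1 to compound 3 (0.02 log units; within the scatter), a change no larger than the scatter, with either direction equally plausible. The estimate for compound 3 in this assay is therefore 6.5 ug/mL, within a range of 2 ug/mL to 20 ug/mL.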

Compound 3, half-maximal inhibitory concentration: 9.66 ug/mL
Estimate against measurement, compound 3: 1.5-fold (0.17 log units) below; low and high end bracket the measured number.
By their numbers in this assay, from the lowest: compounds 2, 1 and 3 (each within the scatter of the next).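

Replacing hydroxyamino with benzylsulfanyl on this aromatic carbon, next to the ring nitrogen, gives in this assay a 1.4-fold higher number from compound 1 to compound 3 (0.15 log units; within the scatter) and so leaves compound 1 and compound 3 indistinguishable. Going by these compounds alone, this is the first direct view of a change at this position, and the change is large in what can be counted: 2 heavy atoms give way to 8, a six-membered aromatic ring enters, and the hydrogen-bond donors go from 2 to 0. For this one pair, then, a much larger group with no hydrogen-bond donors at this carbon leaves no readable mark on the number, and nothing measured here offers an explanation for that.

The sulfur and the benzyl ring enter together, so the compounds shown leave open what each contributes alone; a methylsulfanyl group or a benzylamino group on the same carbon would begin to separate the two. On these data alone, it also remains open whether any group at this position can move the number beyond the scatter, and a plain amine or a carboxylic acid there would test that.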